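The source may hold more compounds than are shown below. What is called first, only, known or untested is meant among the compounds shown, and "the series" means these compounds.

Measured in a functional assay on CHO cells (Cricetulus griseus) for inhibition, read by MTT assay, with a stated time of 96 h; on this read-out higher numbers stand for weaker inhibition and lower numbers for stronger inhibition:
Compound 1 `C=C(C)[C@@H](OC(=O)c1ccc(F)c2ccccc12)C(N)=O`: > 100000 nM, a limit of the assay
Compound 2 `CC1([C@@H](OC(=O)c2ccc(F)c3ccccc23)C(N)=O)CO1`: 7000 nM

Going by the values given here, compound 2 holds the only actual number in this assay. Compound 3 `CC1([C@H](OC(=O)c2ccc(F)c3ccccc23)C(N)=O)CO1` has the same atoms and bonds: the two compounds have the same atoms and bonds; at least one stereo element is drawn with a configuration in one of them and without one in the other: 1 of 2 stereo elements differ; a stereocentre at a saturated chain carbon is drawn R in compound 2 and S in compound 3. Among the compounds with values here, the only measured step, an at least 14-fold lower number from compound 1 to compound 2 (1.15 log units; beyond the scatter), is large, but it reflects a change of group, not of configuration. It therefore gives neither a size nor a direction for this inversion. The expected step, a 1.3-fold higher number from compound 2 to compound 3 (0.11 log units; within the scatter), lies within the scatter, although a larger change in either direction remains possible. For compound 3 the estimated value is 9000 nM, with an expected range of 2500 nM to 40000 nM.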

Compound 3, half-maximal inhibitory concentration: 7000 nM
Compound 3: middle estimate off by 1.3-fold (0.11 log units), on the high side; low and high end bracket the measured number.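

In this assay, inverting the saturated chain carbon gives no change at the digits printed from compound 2 to compound 3 (within the scatter). Within this pair, the configuration drawn at that carbon therefore makes no measurable difference to inhibition, which the earlier comparison of compound 1 with compound 2 could not show. One reservation applies to this reading: the fact that one of compounds 2 and 3 is drawn with a defined configuration and the other without, at the place where they differ

The compounds shown leave open whether the other stereo element matters. They also leave open whether an amine in place of the 2-methyloxiran-2-yl group, or a carboxylic acid in place of the amide, would retain this inhibition.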